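Thiophen-2-yl for furan-3-yl on the shared core

The source may hold more compounds than are shown below. What is called first, only, known or untested is meant among the compounds shown, and "the series" means these compounds.

Measured compounds:
- compound 1, `CC1=C(C(=O)OC(C(F)(F)F)C(F)(F)F)C(c2ccoc2)NC(=O)N1`: 7%
- compound 2, `CC1=C(C(=O)OC(C)C(F)(F)F)C(c2cccs2)NC(=O)N1`: 12%; 16% (2 entries)

Going by the values given here, in an assay on cells for displacement of a labelled ligand from adenosine receptor A1 (Homo sapiens), read by radioligand binding, with a stated time of 60 min, tested at 1 uM (on this read-out lower numbers stand for less inhibition and higher numbers for more inhibition at the one concentration tested (going by the name of the read-out)), compound 1 gives 7%, the only number in the set, with one further entry carrying no single value. Compound 2 sits in the same low region, shown by the several entries of compound 2 in this assay, 12%; 16% (2 entries). Compound 3, `CC1=C(C(=O)OC(C(F)(F)F)C(F)(F)F)C(c2cccs2)NC(=O)N1`, is not yet measured. It differs from compound 1 by thiophen-2-yl in place of furan-3-yl on a saturated ring carbon. Among the compounds with values here, no pair of measured compounds differs in one place, so no step size is known from data. The step from compound 1 to compound 3 is expected to stay within scatter, a number 3 percentage points higher from compound 1 to compound 3 (within the scatter). Compound 3 is estimated at 10%, between 0% and 25%.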

Compound 3, a percentage reported as inhibition, at one concentration (the size of the read-out at that concentration, not a potency): 9%
Compound 3: middle estimate off by 1 percentage points, on the high side, within the range that was stated.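

In this assay, the only single-place step shown gives a number 2 percentage points higher from compound 1 to compound 3 (within the scatter), so thiophen-2-yl and furan-3-yl on this saturated ring carbon cannot be told apart at the one concentration tested. Swapping one five-membered aromatic ring for the other leaves compound 3 in the low region, where compound 2, which also carries thiophen-2-yl, stands: the several entries of compound 2 in this assay, 12%; 16% (2 entries)

Open remains how a phenyl or pyridyl ring, an amine or a carboxylic acid on this carbon would read. Also open, as far as these compounds go, is whether any change at this position moves the inhibition beyond the scatter.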